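The compounds below may be only part of what the source reports. "The series", "measured", "known", "first", "only" and "open" are said of these compounds alone.

Compound 1 `Cc1ccc(CNc2ccc(CCC(=O)O)cc2)cc1` gives 3980 nM in a functional assay for agonist activity at Free fatty acid receptor 1 (Homo sapiens); on this read-out lower numbers stand for an effect already at smaller amounts and higher numbers for an effect only at larger amounts of compound.
Compound 2 `O=C(O)CCc1ccc(NCc2ccc(C(=O)O)cc2)cc1` gives < 31700 nM in this assay, which is a limit of the assay and not a number.

In this assay compound 2 stands only at a limit, (the limit of < 31700 nM in this assay, at which 1 of the 2 values shown sits), so no number is known for it. The step that the limit leaves unreadable from compound 1 to compound 2 is therefore unreadable. Compound 3 `N#Cc1ccc(CNc2ccc(CCC(=O)O)cc2)cc1` differs from compound 2 by cyano in place of carboxy on an aromatic carbon. Going by the values given here, no measured step bears on this change, and the one recorded step cannot be read. Compound 1 gives 3980 nM, and compound 3 is expected to sit somewhat weaker than that. The step that the limit leaves unreadable from compound 2 to compound 3 is only an estimate. Compound 3 is expected at 8000 nM, between 2000 nM and 40000 nM.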

Compound 3, half-maximal effective concentration: < 31700 nM
Compound 3 was reported as a limit; the forecaster's own chance of this, stated with the estimate: 35%; the middle value is on the limit's open side.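

Compound 3, like compound 2, stands only at a limit and not at a number, so no new step among compound 1, compound 2 and compound 3 can be read: the limit of < 31700 nM in this assay, at which 2 of the 3 values shown sit.

The compounds shown leave open how far compound 2 and compound 3 actually lie from compound 1 in this assay.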